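A Double Bond Redrawn in a Growth Inhibitor

The compounds below may be only part of what the source reports. "The series", "measured", "known", "first", "only" and "open" are said of these compounds alone.

In a functional assay on MCF7 cells (Homo sapiens) for inhibition, read by trypan blue exclusion, with a stated time of 72 h (a lower number here means a stronger inhibitor of growth, a higher number a weaker inhibitor of growth), compound 1 `CC/C(=C(\c1ccccc1)c1ccc(NC(=O)C(C)C)cc1)c1ccc(Cl)cc1Cl` gives 8300 nM. Compound 2 `CC/C(=C(/c1ccc(NC(=O)C(C)C)cc1)c1ccc(OC)cc1)c1ccc(Cl)cc1Cl` carries a methoxy in place of hydrogen on an aromatic carbon, and in this assay compound 2 gives 6600 nM. For the measured compounds named here, the measured step is a 1.3-fold lower number from compound 1 to compound 2 (0.10 log units; within the scatter), so compound 2 stands level with compound 1, the only other compound measured.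

Compound 3 `CC/C(=C(\c1ccc(NC(=O)C(C)C)cc1)c1ccc(OC)cc1)c1ccc(Cl)cc1Cl` is the next to be considered. The structural change is the two compounds have the same atoms and bonds and differ only in configuration as drawn: 1 of 1 stereo elements differ; a double bond is drawn E in compound 2 and Z in compound 3: a double bond is drawn E in compound 2 and Z in compound 3. Going by the values given here, the single measured step bears on this only indirectly, since it exchanges a substituent and leaves the configuration as it is. Among the compounds with values here, no measured pair shows what a change of configuration does in this assay. With no evidence for either direction, no shift beyond the scatter is expected, though this expectation is held loosely and the range is kept wide. The estimated step is no change at the digits printed from compound 2 to compound 3 (within the scatter). For compound 3 the expected value is 6600 nM, with an estimated range of 2800 nM to 15000 nM.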

Compound 3, concentration for 50% growth inhibition: 13200 nM
Compound 3: the middle estimate sits 2.0-fold (0.30 log units) below what was measured; the measured number falls inside the stated range.
By their numbers in this assay, from the lowest: compounds 2, 1 and 3 (each within the scatter of the next).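

For the compounds shown here, compounds 2 and 3 give the first reading of what a change of configuration alone does in this assay: a 2.0-fold higher number from compound 2 to compound 3 (0.30 log units; within the scatter). This pair isolates the double bond, as no group enters or leaves and the comparison rests on one structural difference: the fact that compounds 2 and 3 differ only in the configuration as drawn. At this double bond, then, redrawing the configuration gives a step that stays within the scatter, as does the exchange of hydrogen for methoxy in the earlier step, a 1.3-fold lower number from compound 1 to compound 2 (0.10 log units; within the scatter), so neither single change shown here separates its two compounds in this assay.

The compounds shown leave open whether this result holds for the configuration of the double bond when the methoxy is replaced by another group, such as a hydroxyl, an amine or a carboxylic acid. They also leave open whether any such group, or a longer chain in place of the ethyl on the double bond, would give a step beyond the scatter in either configuration.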